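Adding a hydroxy group to compound 3

The source may hold more compounds than are shown below. What is called first, only, known or untested is meant among the compounds shown, and "the series" means these compounds.

Compound 1, `Cc1cccc(NC(=O)CN2CCC(c3nccs3)CC2)c1`: 62%
Compound 2, `Cc1cccc(NC(=O)CN2CCC(c3cccc(F)c3)CC2)c1`: 40%
Compound 3, `Cc1cccc(NC(=O)CN2CCC(c3ccccc3)CC2)c1`: 37%

In a functional assay on HEK293 cells for agonist activity at D(4) dopamine receptor (Homo sapiens), read by FLIPR (a higher number here means a larger maximal response, a lower number a smaller maximal response), compound 3 stands lowest of the three numbers. Compound 2 lies within the scatter of it, while compound 1 sits clearly above, as a number 25 percentage points lower from compound 1 to compound 3 (beyond the scatter) shows. Compound 4, `Cc1cccc(NC(=O)CN2CCC(c3cccc(O)c3)CC2)c1`, differs from compound 3 by hydroxy in place of hydrogen on an aromatic carbon. Among the measured compounds shown here, the one measured step on the same aromatic ring is a number 3 percentage points lower from compound 2 to compound 3 (within the scatter), which stays within the scatter. The other steps, a number 22 percentage points lower from compound 1 to compound 2 (beyond the scatter) and a number 25 percentage points lower from compound 1 to compound 3 (beyond the scatter), concern the exchange of a whole ring and bear less on this small change. The step of a number 3 percentage points higher from compound 3 to compound 4 (within the scatter) is therefore expected to stay within the scatter. Compound 4 is estimated at 40%, with an expected range from 25% to 55%.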

Compound 4, largest response reached (reported as efficacy), in percent of the reference or control that the assay uses: 66%
Compound 4: the middle estimate sits 26 percentage points below what was measured; the whole stated range lies below it.
By their numbers in this assay, from the lowest: compounds 3 and 2 (each within the scatter of the next); then compounds 1 and 4 (each within the scatter of the next).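

Hydroxy in place of hydrogen gives a number 29 percentage points higher from compound 3 to compound 4 (beyond the scatter), and hydroxy in place of fluoro gives a number 26 percentage points higher from compound 2 to compound 4 (beyond the scatter), so this position on the aromatic ring does respond to its substituent, which a number 3 percentage points lower from compound 2 to compound 3 (within the scatter) had not revealed. The change also closes the gap to the thiazole compound, with a number 4 percentage points higher from compound 1 to compound 4 (within the scatter). In this assay, then, the 3-hydroxyphenyl group and the 1,3-thiazol-2-yl group stand level.

Nothing available explains why hydroxy differs from fluoro and hydrogen here. On these data alone, whether methoxy or an amine at this position would give a similar response remains open.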